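Swapping a fluorinated ring for a saturated one

This account rests on a few compounds, and the source may have more. Where it says the series, first, only, none or still open, it means among the compounds named here.

Of the compounds shown here, three share one core and have been tested in a functional assay on A549 cells (Homo sapiens) for inhibition, read by XTT assay, with a stated time of 48 h; on this read-out higher numbers stand for weaker inhibition and lower numbers for stronger inhibition. Compound 1 `COc1ccc(C(=O)/C(=C/c2ccc(Cl)cc2)CCOC(C)=O)cc1` gives 86000 nM. Compound 2 `C=C(C(=O)c1ccc(OC)cc1)C(OC(C)=O)c1ccccc1F` gives 67300 nM, and compound 3 `C=C(C(=O)c1ccc(OC)cc1)C(OC(=O)c1ccccc1)c1ccccc1F` gives 73700 nM. Compound 3 therefore stands second highest of the three numbers, yet its gaps to compound 2 and to compound 1 both fall within the usual scatter, so no order among the three can be claimed. Among the measured compounds shown here, the only step between neighbours that differ in one place, a 1.1-fold higher number from compound 2 to compound 3 (0.04 log units; within the scatter), changed the group on the carbonyl carbon and left the number essentially unmoved.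

Compound 4 `C=C(C(=O)c1ccc(OC)cc1)C(OC(=O)c1ccccc1)C1CCCCC1` differs from compound 3 by cyclohexyl in place of 2-fluorophenyl on a saturated chain carbon bound to a double-bonded chain carbon and an oxygen next to a carbonyl group. None of the measured steps touches this position, so the change in this assay has no direct precedent among the compounds shown. With all three numbers sitting close together, a step of a 1.0-fold higher number from compound 3 to compound 4 (0.01 log units; within the scatter) is expected, meaning no shift beyond the scatter, and compound 4 is estimated at 75000 nM, with a range from 30000 nM to 200000 nM.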

Compound 4, half-maximal inhibitory concentration: 62100 nM
Compound 4: the middle estimate sits 1.2-fold (0.08 log units) above what was measured; measured number inside the range.
By their numbers in this assay, from the lowest: compounds 4, 2, 3 and 1 (each within the scatter of the next).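

Among the compounds shown here, putting cyclohexyl in place of 2-fluorophenyl on this saturated chain carbon gives a 1.2-fold lower number from compound 3 to compound 4 (0.07 log units; within the scatter) in this assay, the first measured change at this position. For this pair, then, neither the aromatic ring nor the fluorine is needed to keep the number where it is: a non-aromatic ring of carbon only reads the same as the fluorinated aromatic one. Nothing available explains why the two rings read alike.

Going by these compounds, it remains open whether a very different group at this position, such as an amine, a carboxylic acid or a longer open chain, would move the number beyond the scatter. Also open, on these data alone, is whether the same swap would read alike with the acetate ester of compound 2 in place of the benzoate ester of compound 3.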